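A few compounds are considered here, and "the series" means these few. Any claim that something is new, unique, unknown or untested is made for them only; others in the source may bear on it.

Four compounds are compared in an ADME assay on MT4 cells (Homo sapiens) for cytotoxicity; a higher number here means that more compound is tolerated, a lower number that less compound is tolerated. Compound 1, with the structure `Cc1cc(C)cc(S(=O)(=O)n2c(SCC(=O)Nc3ccccc3[N+](=O)[O-])nc3ccccc32)c1`, carries a nitro-substituted anilide on a sulfur-linked side chain and a sulfonyl group on the shared core. In this assay compound 1 reaches only the limit of >= 26000 nM, which is a boundary of the measurement rather than a number. Compound 2, with the structure `Cc1cc(C)cc(S(=O)(=O)n2c(SCC(=O)Nc3ccccc3[N+](=O)[O-])nc3ccc(Cl)cc32)c1`, is built from compound 1 by the change (chloro in place of hydrogen on an aromatic carbon). In this assay compound 2 also stops at a limit, > 235000 nM. Because both readings are limits, as the lines the limit of > 235000 nM in this assay, at which 1 of the 3 values shown sits, and the limit of >= 26000 nM in this assay, at which 1 of the 3 values shown sits, show, the step that the two limits leave unreadable from compound 1 to compound 2 cannot be read from these two compounds.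

Compound 3, with the structure `Cc1cc(C)cc(Cn2c(SCC(=O)Nc3ccc(S(C)(=O)=O)cc3Cl)nc3ccccc32)c1`, has a different core and side chain; how its core differs from that of compound 1 is not broken down here. In this assay, among the measured compounds shown here, compound 3 gives 106000 nM, the only plain number among the three measured compounds.

Compound 4, with the structure `Cc1cc(C)cc(Cn2c(SCC(=O)Nc3ccc(S(C)(=O)=O)cc3Cl)nc3ccc(Cl)cc32)c1`, is made from compound 3 by the same change, (chloro in place of hydrogen on an aromatic carbon). The measured pair gives no readable size for this change, so the expectation for compound 4 rests mainly on the value of compound 3, 106000 nM, and the step from compound 3 to compound 4 is estimated to be small, a 1.1-fold higher number from compound 3 to compound 4 (0.05 log units; within the scatter). Compound 4 is therefore expected to give about 120000 nM, most likely between 50000 nM and 300000 nM.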

Compound 4, half-maximal cytotoxic concentration: 88800 nM
Estimate against measurement, compound 4: 1.4-fold (0.13 log units) above; the range from low to high includes it.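

In this assay, putting chloro in place of hydrogen on an aromatic carbon of the core shared by compound 3 and compound 4 gives a 1.2-fold lower number from compound 3 to compound 4 (0.08 log units; within the scatter); on this core, the two compounds cannot be told apart in this read-out. Compound 2, which carries the same change on the core of compound 1, stops at a limit of the assay rather than a number: the limit of > 235000 nM in this assay, at which 1 of the 4 values shown sits. Among the compounds shown here, compound 1 also stops at a limit rather than a number, so the step on that core cannot be read, and the one readable step does not show whether the change carries over from one core to the other: the limit of >= 26000 nM in this assay, at which 1 of the 4 values shown sits.

Only hydrogen and chloro appear at this place on the ring, which leaves open how this assay would read with another group there, such as an amine, a carboxylic acid or a longer chain. Going by these compounds, compound 1 and compound 3 differ in more than one place, and the effect of the core alone on tolerance in this assay also remains open.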